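The compounds below may be only part of what the source reports. "The series", "measured", "known", "first", "only" and "open" are said of these compounds alone.

Series notes. Among the measured compounds shown here, in an ADME assay on HepG2 cells (Homo sapiens) for cytotoxicity, read by luminescence, CellTiter-Glo and ATP content, with a stated time of 72 h (on this read-out higher numbers stand for an effect only at larger amounts of compound and lower numbers for an effect already at smaller amounts), compound 3 `COc1cccc(CNCCCNc2ccnc3cc(-c4cccc5ccccc45)ccc23)c1O` gives 2520 nM, the lowest of the three numbers so far; compound 2 `CC(C)(C)c1ccc(-c2ccc3c(NCCCNCc4ccco4)ccnc3c2)cc1` gives 3150 nM, within the scatter of compound 3, while compound 1 `COc1cccc(CNCCCNc2ccnc3cc(Cc4ccccc4)ccc23)c1O` gives 5720 nM, beyond it. For the measured compounds named here, the only measured step with a single change at this place is a 2.3-fold lower number from compound 1 to compound 3 (0.36 log units; beyond the scatter). Compound 4 `COc1cccc(CNCCCNc2ccnc3cc(-c4ccc(C(C)(C)C)cc4)ccc23)c1O` differs from compound 3 by 4-(tert-butyl)phenyl in place of naphthalen-1-yl on an aromatic carbon. Going by the values given here, this is again a swap of one aryl group for another on the same carbon, so a modest step at most is what the one measured step supports, and compound 2 carries the same entering group with another chain and gives a number close to that of compound 3. Compound 4 is therefore expected to give 3200 nM (range 1300 nM to 8000 nM), the expected step of a 1.3-fold higher number from compound 3 to compound 4 (0.10 log units; within the scatter) lying within the scatter.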

Compound 4, half-maximal effective concentration: 690 nM
Beside the measured number, compound 4's estimate is 4.6-fold (0.67 log units) above it; measured number below the stated range.
By their numbers in this assay, from the lowest: compound 4; then compounds 3, 2 and 1 (each within the scatter of the next, the first and the last beyond it).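

In this assay, this aromatic carbon of the core responds to more than the presence of an aryl group: with the same heavy-atom count leaving and entering, 4-(tert-butyl)phenyl in place of naphthalen-1-yl gives a 3.7-fold lower number from compound 3 to compound 4 (0.56 log units; beyond the scatter), and in place of benzyl it gives an 8.3-fold lower number from compound 1 to compound 4 (0.92 log units; beyond the scatter). With 4-(tert-butyl)phenyl held constant, the far end of the chain also matters, as 2-hydroxy-3-methoxyphenyl in place of furan-2-yl gives a 4.6-fold lower number from compound 2 to compound 4 (0.66 log units; beyond the scatter). No available evidence accounts for these steps.

On these data alone, it remains open whether the tert-butyl group or the single aromatic ring carries the change. Plain phenyl, or an amine or carboxylic acid in place of tert-butyl, would separate these.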